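The compounds below may be only part of what the source reports. "The series", "measured", "known", "first", "only" and "open" are said of these compounds alone.

Measured compounds:
compound 1 `CCn1c(C(=O)N(C)CCC#N)ccc1C(CC)(CC)c1ccc(OCC(=O)C(C)(C)C)c(C)c1`, in an assay on HL-60 cells for agonist activity at vitamin D3 receptor (Homo sapiens), read by microscopy, with a stated time of 96 h (a higher number here means that more compound is needed for the effect, a lower number that less compound is needed), compound 1 gives 9800 nM
compound 2 `C=CCN(C)C(=O)c1ccc(C(CC)(CC)c2ccc(OCC(=O)C(C)(C)C)c(C)c2)n1CC`, compound 2 gives 21600 nM
compound 3 `CCn1c(C(=O)NCCN(C)C)ccc1C(CC)(CC)c1ccc(OCC(O)C(C)(C)C)c(C)c1`, compound 3 gives 14 nM

Compound 3 stands lowest of the three; the other two lie far higher, compound 1 nearer and compound 2 furthest. Compounds 1 and 2 also carry a ketone on the aryl ether chain where compound 3 carries an alcohol, so the gap to compound 3 cannot be assigned to one place.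

Compound 4 `C#CC(C)OC(=O)c1ccc(C(CC)(CC)c2ccc(OCC(O)C(C)(C)C)c(C)c2)n1CC` is not yet measured. It differs from compound 3 in one place: (1-methylprop-2-yn-1-yl)oxy in place of (2-(dimethylamino)ethyl)amino on a carbonyl carbon. Among the compounds with values here, the one measured step, a 2.2-fold higher number from compound 1 to compound 2 (0.34 log units; beyond the scatter), concerns a substituent on the amide-type nitrogen and is modest; no measured step replaces the whole group on the carbonyl carbon, so it bears on this change only loosely.

Within the data shown here, since the change is larger than the one measured step, a step beyond the scatter is expected, and in the direction of a higher number, a 5.0-fold higher number from compound 3 to compound 4 (0.70 log units; beyond the scatter). The value of compound 4 in this assay is estimated at 70 nM, within a range from 10 nM to 500 nM.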

Compound 4, half-maximal effective concentration: 200 nM
For compound 4 the middle estimate is 2.9-fold (0.46 log units) below the measured one; measured number inside the range.
By their numbers in this assay, from the lowest: compound 3; then compound 4; then compound 1; then compound 2.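

With the alcohol on the aryl ether chain held constant, the group on the carbonyl carbon alone moves the number in this assay: a 14-fold higher number from compound 3 to compound 4 (1.15 log units; beyond the scatter). This step is far larger than the only earlier one, a 2.2-fold higher number from compound 1 to compound 2 (0.34 log units; beyond the scatter), so replacing the whole group matters more here than changing a substituent on the amide-type nitrogen did in the ketone pair. No supporting measurement accounts for the size of the step.

The change swaps the linking nitrogen for oxygen and the dimethylamino end for a triple-bonded end at once, and a 2-(dimethylamino)ethoxy group on the carbonyl carbon would separate those two parts. What the alcohol contributes in place of the ketone also stays open, as no pair shown differs in that place alone.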